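From pyrazin-2-yl to 1,2,4-oxadiazol-3-yl: estimating clearance

This account rests on a few compounds, and the source may have more. Where it says the series, first, only, none or still open, it means among the compounds named here.

Of the compounds shown here, three sharing one core have been measured in an in vivo ADME assay on the whole organism (strain 129/SvEvBrd x C57BL/6) for pharmacokinetics, with Mus musculus as the target, at a dose of 1 mg/kg by the intravenous route; on this read-out lower numbers stand for slow clearance and higher numbers for fast clearance. Compound 1 `CN(C)C(=O)c1nc([C@@H](O)[C@H](O)[C@H](O)CO)c[nH]1` gives 11.3 mL/min/kg, compound 2 `OC[C@@H](O)[C@@H](O)[C@H](O)c1c[nH]c(-c2ncc[nH]2)n1` gives 31.5 mL/min/kg, and compound 3 `OC[C@@H](O)[C@@H](O)[C@H](O)c1c[nH]c(-c2cnccn2)n1` gives 13.4 mL/min/kg. Compound 3 therefore belongs to the lower pair of these numbers.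

Compound 4 `OC[C@@H](O)[C@@H](O)[C@H](O)c1c[nH]c(-c2ncon2)n1` differs from compound 3 at one place, with 1,2,4-oxadiazol-3-yl in place of pyrazin-2-yl on an aromatic carbon.

Three measured steps involve the same carbon. Exchanging the dimethylcarbamoyl group gave a 2.8-fold higher number from compound 1 to compound 2 (0.45 log units; beyond the scatter) with 1H-imidazol-2-yl and a 1.2-fold higher number from compound 1 to compound 3 (0.07 log units; within the scatter) with pyrazin-2-yl. Exchanging 1H-imidazol-2-yl for pyrazin-2-yl gave a 2.4-fold lower number from compound 2 to compound 3 (0.37 log units; beyond the scatter). None of these steps involves 1,2,4-oxadiazol-3-yl, and the largest is only modest, so the direction remains uncertain. Starting from compound 3 at 13.4 mL/min/kg, the expected change is small, with no shift beyond the scatter: a 1.1-fold higher number from compound 3 to compound 4 (0.05 log units; within the scatter). The estimated clearance of compound 4 is 15 mL/min/kg, within an expected range of 8 mL/min/kg to 30 mL/min/kg.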

Compound 4, clearance: 11.3 mL/min/kg
Estimate against measurement, compound 4: 1.3-fold (0.12 log units) above; the range from low to high includes it.
By their numbers in this assay, from the lowest: compounds 1, 4 and 3 (each within the scatter of the next); then compound 2.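

In this assay the exchange of pyrazin-2-yl for 1,2,4-oxadiazol-3-yl gives a 1.2-fold lower number from compound 3 to compound 4 (0.07 log units; within the scatter) and so shows that this carbon, between two ring nitrogen atoms, can carry a five-membered aromatic ring with 3 hetero atoms in place of a six-membered one with no shift beyond the scatter. Set against dimethylcarbamoyl the same group gives no change at the digits printed from compound 1 to compound 4 (within the scatter) and set against 1H-imidazol-2-yl it gives a 2.8-fold lower number from compound 2 to compound 4 (0.45 log units; beyond the scatter) on this read-out. Compounds 1, 3 and 4 thus lie within the scatter of one another, and among the four groups seen here only the 1H-imidazol-2-yl of compound 2 stands apart.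

Nothing shown gives a reason for these numbers. Going by these compounds, whether an amine or a carboxylic acid on this carbon would fall with compounds 1, 3 and 4 or with compound 2 stays open.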